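From cycloheptyl to pentyl on a shared core

A few compounds are considered here, and "the series" means these few. Any claim that something is new, unique, unknown or untested is made for them only; others in the source may bear on it.

Compound 3 `O=C(NCc1ccc(-c2noc(C3CCCCCC3)n2)cc1)[C@H]1NCC[C@@H]1O` reads > 50 ug/mL in a physicochemical assay for solubility, at pH 7.4 (on this read-out lower numbers stand for lower solubility and higher numbers for higher solubility), and that reading is a limit, not a number. Compound 4 `CCCCCc1nc(-c2ccc(CNC(=O)[C@H]3NCC[C@@H]3O)cc2)no1` has pentyl in place of cycloheptyl on an aromatic carbon and is otherwise the same. Among the measured compounds shown here, no measured pair shows this change alone. The nearest guides are compound 1 `CCCCCCCc1nc(-c2ccc([C@@H](C)NC(=O)[C@H]3NCC[C@@H]3O)cc2)no1` at 27 ug/mL and compound 2 `CCCCCCCc1noc(-c2ccc(CNC(=O)[C@H]3NCC[C@@H]3O)cc2)n1` at 3 ug/mL with their open heptyl chains, although each also differs from compound 3 elsewhere. Both numbers sit under that limit, so a moderate fall is expected, and the estimated change is an at least 1.6-fold lower number from compound 3 to compound 4 (0.22 log units; that floor lies within the scatter) in this assay on this evidence. Compound 4 is expected to read 30 ug/mL within an estimated range from 10 ug/mL to 60 ug/mL on this scale.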

Compound 4, solubility: > 50 ug/mL
Compound 4 was reported as a limit (the forecaster's own chance of this, stated with the estimate: 25%); at least 1.6-fold (0.22 log units) between middle value and limit.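

Among the compounds shown here, compound 3 and compound 4 both read only as limits in this assay, so no step between them can be read: the limit of > 50 ug/mL in this assay, at which 2 of the 4 values shown sit. From the compounds shown here alone, whether pentyl in place of cycloheptyl on an aromatic carbon changes the reading at all stays open.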